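The source may hold more compounds than are shown below. What is called first, only, known or untested is meant among the compounds shown, and "the series" means these compounds.

In a functional assay on PC-3 cells (Homo sapiens) for inhibition, read by sulforhodamine B assay (a lower number here means a stronger inhibitor of growth, a higher number a weaker inhibitor of growth), compound 1 (`COc1cc(-c2ccc(-c3ccc(-c4nc5cc(C)ccc5[nH]4)cc3)cc2)cc(OC)c1OC`) gives 180 nM and compound 2 (`Fc1ccc(-c2ccc(-c3ccc(-c4nc5ccccc5[nH]4)cc3)cc2)cc1`) gives 41200 nM, the higher of the two numbers and beyond the scatter of compound 1. Compound 3 (`COc1ccc(-c2ccc(-c3ccc(-c4nc5ccccc5[nH]4)cc3)cc2)cc1`) has methoxy in place of the fluoro of compound 2 on an aromatic carbon, para to a large group: methoxy in place of fluoro on an aromatic carbon. Compound 1 also carries methoxy groups and reads 180 nM, so a moderate fall beyond the scatter is expected, although compound 1 differs elsewhere too. The expected step is a 5.2-fold lower number from compound 2 to compound 3 (0.71 log units; beyond the scatter). Compound 3 is estimated at 8000 nM, with an expected range of 1500 nM to 40000 nM.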

Compound 3, concentration for 50% growth inhibition: 100000 nM
Compound 3: the middle estimate sits 13-fold (1.10 log units) below what was measured, outside the stated range (above it).
By their numbers in this assay, from the lowest: compound 1; then compound 2; then compound 3.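

In this assay methoxy in place of fluoro on an aromatic carbon, para to a large group, gives a 2.4-fold higher number from compound 2 to compound 3 (0.39 log units; beyond the scatter) and so weakens growth inhibition at this position. A single methoxy here offers no gain over fluoro, and compound 1 differs from both in more than one place, so its number cannot be tied to this change. No available data explain the step.

Open, going by these compounds, is whether an amine or a carboxylic acid at this position would read differently from fluoro and methoxy. Also open, on these data alone, is whether methoxy in place of fluoro gives the same step on the core of compound 1.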